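Compound 4: an expected value from compound 2

The source may report more compounds than this note shows. Statements on the series, on what has been measured and on what is new or still open speak of the compounds shown alone.

Measured in an ADME assay on HEK-293T cells (Homo sapiens) for cytotoxicity, read by CCK-8 assay, with a stated time of 48 h (on this read-out higher numbers stand for weaker inhibition and lower numbers for stronger inhibition), so far
- compound 1 `COc1ccc(Oc2ccc(C(C)C)cc2-c2ccsc2S(=O)(=O)NCCNC(=S)Nc2ccc([N+](=O)[O-])cc2)cc1OC` gives 11400 nM
- compound 2 `COc1ccc(Oc2ccc(C(C)C)cc2-c2ccsc2S(=O)(=O)NCCNC(=O)Nc2cc(Cl)cc(Cl)c2)cc1OC` gives 11900 nM
- compound 3 `COc1ccc(Oc2ccccc2-c2ccsc2S(=O)(=O)N2CCN(C(=O)Nc3ccc([N+](=O)[O-])cc3)CC2)cc1OC` gives > 20000 nM (a limit of the assay, not a number)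

Within the data shown here, compound 2 stands level with compound 1, and these are the only two numbers available. Among the measured compounds shown here, the one measured step between them is a 1.0-fold higher number from compound 1 to compound 2 (0.02 log units; within the scatter) and it replaces a group on an amine nitrogen. Compound 3 is reported only as a limit (> 20000 nM).

Compound 4 `CC(C)c1ccc(Oc2ccc(O)c(O)c2)c(-c2ccsc2S(=O)(=O)NCCNC(=O)Nc2cc(Cl)cc(Cl)c2)c1` differs from compound 2 by 3,4-dihydroxyphenyl in place of 3,4-dimethoxyphenyl on an oxygen on an aromatic ring and so carries 3,4-dihydroxyphenyl in place of 3,4-dimethoxyphenyl on an oxygen on an aromatic ring. For the measured compounds named here, no measured step touches this group, so the evidence for its effect is thin. With compound 2 at 11900 nM as the anchor, no change beyond the scatter is expected in this assay, though the uncertainty stays wide. The estimated step is a 1.2-fold lower number from compound 2 to compound 4 (0.08 log units; within the scatter) in this expectation. For compound 4 the expected value is 10000 nM with an estimated range from 4000 nM to 20000 nM in this assay.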

Compound 4, half-maximal inhibitory concentration: > 10000 nM
Compound 4: only a limit was reported; the forecaster's own chance of this, stated with the estimate: 12%; the middle value sits exactly at the limit.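

In this assay compound 4 gives > 10000 nM, which is a limit of the assay and not a number. The step from compound 2 to compound 4 therefore cannot be read. The compounds shown leave open whether, and how far, 3,4-dihydroxyphenyl in place of 3,4-dimethoxyphenyl changes the number in this assay.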